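The source may hold more compounds than are shown below. What is called first, only, known or untested is meant among the compounds shown, and "the series" means these compounds.

For the measured compounds named here, compound 3 `CCOc1nc(-c2cc3ccccc3o2)cc(-c2ccc(Br)cc2)c1C#N` gives 227000 nM in a functional assay on aorta (strain Wistar) for inhibition, with Thoracic aorta (Rattus norvegicus) as the target (a lower number here means a stronger inhibitor, a higher number a weaker inhibitor), the lowest of the three numbers measured so far, though its separation from the others stays within the scatter. Compound 1 `CCOc1nc(-c2cc3ccccc3o2)cc(-c2ccccc2)c1C#N` gives 310000 nM, and compound 2 `CCOc1nc(-c2cc3ccccc3o2)cc(-c2cccc3ccccc23)c1C#N` gives 344000 nM. The step of a 1.4-fold lower number from compound 1 to compound 3 (0.14 log units; within the scatter) and the step of a 1.5-fold lower number from compound 2 to compound 3 (0.18 log units; within the scatter) both change the same six-membered ring that compound 4 varies, and neither moves the number beyond the scatter; the step of a 1.1-fold higher number from compound 1 to compound 2 (0.05 log units; within the scatter) does not either. Compound 4 `CCOc1nc(-c2cc3ccccc3o2)cc(-c2ccc(OC)cc2)c1C#N` differs from compound 3 by methoxy in place of bromo on an aromatic carbon. Since every change tried so far at the para position of this ring, including bromo in place of hydrogen, has left this assay unchanged beyond the scatter, the expected step of a 1.1-fold higher number from compound 3 to compound 4 (0.02 log units; within the scatter) is no step beyond the scatter. Compound 4 is therefore estimated at 240000 nM, with a range from 110000 nM to 520000 nM, in this assay.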

Compound 4, half-maximal inhibitory concentration: 204000 nM
For compound 4 the middle estimate is 1.2-fold (0.07 log units) above the measured one; low and high end bracket the measured number.
By their numbers in this assay, from the lowest: compounds 4, 3, 1 and 2 (each within the scatter of the next).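

Methoxy in place of bromo adds a hydrogen-bond acceptor on the six-membered aromatic ring of carbon only, para to a large group, yet this assay shows a 1.1-fold lower number from compound 3 to compound 4 (0.05 log units; within the scatter) and thus no separation. Methoxy in place of hydrogen likewise gives a 1.5-fold lower number from compound 1 to compound 4 (0.18 log units; within the scatter) and 4-methoxyphenyl in place of naphthalen-1-yl gives a 1.7-fold lower number from compound 2 to compound 4 (0.23 log units; within the scatter), so all four compounds now lie within the scatter of one another, whether this place carries a hydrogen-bond acceptor or not. No evidence that would explain this result is available.

On these data alone, whether an amine or a carboxylic acid at this place would move the number beyond the scatter in this assay remains open. As far as these compounds go, the ethoxy group and the nitrile stay the same throughout, so the effect of a longer chain in place of ethoxy is also open.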